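Series notes: amide in place of urea on compound 2

The source may hold more compounds than are shown below. What is called first, only, known or untested is meant among the compounds shown, and "the series" means these compounds.

Among the compounds with values here, compound 2 `COc1cc(Cl)cc(-c2nn(-c3cccc(NC(=O)Nc4ccc(Cl)c(Cl)c4)c3)cc2-c2ccncc2)c1` is one of two compounds measured in a functional assay on SK-MEL-28 cells (Homo sapiens) for inhibition, read by sulforhodamine B assay, with a stated time of 48 h, tested at 0.1 uM; on this read-out lower numbers stand for a stronger effect and higher numbers for a weaker effect at the one concentration tested. Compound 2 gives 103%, and compound 1 `O=C(Nc1cccc(-n2cc(-c3ccncc3)c(-c3cc(O)cc(Cl)c3)n2)c1)Nc1ccc(Cl)c(Cl)c1` gives 97%; the step of a number 6 percentage points higher from compound 1 to compound 2 (within the scatter) lies within the scatter, so the two numbers are not told apart. Compound 3 `COc1cc(Cl)cc(-c2nn(-c3cccc(NC(=O)c4cccc(C(F)(F)F)c4)c3)cc2-c2ccncc2)c1` is not yet measured. It differs from compound 2 by 3-(trifluoromethyl)phenyl in place of (3,4-dichlorophenyl)amino on a carbonyl carbon. Within the data shown here, no measured step touches this part of the molecule: the only step in hand, a number 6 percentage points higher from compound 1 to compound 2 (within the scatter), concerns methyl in place of hydrogen on an oxygen on an aromatic ring and was within the scatter. The expectation therefore rests on the level of the two measured compounds alone. Because compound 2 gives 103% and compound 1 gives 97%, compound 3 is expected to stay near the same level, with a number 5 percentage points lower from compound 2 to compound 3 (within the scatter) as the estimated step and no shift beyond the scatter foreseen. Compound 3 is estimated at 98%, within 80% to 112%.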

Compound 3, a percentage reported as activity, at one concentration (the size of the read-out at that concentration, not a potency): 97%
Estimate against measurement, compound 3: 1 percentage points above; low and high end bracket the measured number.
By their numbers in this assay, from the lowest: compounds 1, 3 and 2 (each within the scatter of the next).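

Within the data shown here, this is the first reading at the group on the carbonyl carbon: in this assay, 3-(trifluoromethyl)phenyl in place of (3,4-dichlorophenyl)amino gives a number 6 percentage points lower from compound 2 to compound 3 (within the scatter) and so does not tell the amide of compound 3 from the urea of compound 2 at this one concentration. The exchange removes the hydrogen-bond donor counted on (3,4-dichlorophenyl)amino, yet the two numbers stay within the scatter of each other, so this read-out shows no dependence on that donor in this pair. Nothing at hand gives a cause for this result.

The compounds shown contain no step beyond the scatter, so which part of the molecule can move this read-out stays open. Also open, from the compounds shown here alone, is whether a carboxylic acid or an amine in place of 3-(trifluoromethyl)phenyl on the carbonyl carbon would separate from compound 3.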